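A few compounds are considered here, and "the series" means these few. Any claim that something is new, unique, unknown or untested is made for them only; others in the source may bear on it.

Compound 1 `O=Cc1c(-c2ccccc2)sc2ccccc12` and compound 2 `O=Cc1c(-c2ccc(Cl)cc2)sc2ccccc12` share a core that carries an aldehyde, and they differ only in whether a chloro group is present on the attached ring. In a functional assay on MCF7R cells (Homo sapiens) for cytotoxicity, tested at 10 uM (a lower number here means less inhibition, a higher number more inhibition at the concentration tested (going by the name of the read-out)), compound 1 gives 37%, and compound 2 gives 35%. The structural difference between them is hydrogen in place of chloro on an aromatic carbon, and the measured step is a number 2 percentage points higher from compound 2 to compound 1 (within the scatter). Compound 3 `N#Cc1c(-c2cccc(Cl)c2)sc2ccccc12` carries a nitrile in place of the aldehyde; the difference between the core of compound 3 and the core of compound 2 is not broken down here. In this assay compound 3 gives 20%, the lowest of the three numbers.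

Compound 4 `N#Cc1c(-c2ccccc2)sc2ccccc12` has not yet been measured. It differs from compound 3 by hydrogen in place of chloro on an aromatic carbon. Among the measured compounds shown here, this is the same kind of change as the one from compound 2 to compound 1, but not the same: in the earlier pair the place was para to a large group, whereas here it is meta to a large group. The earlier step was within the scatter, and the expectation for compound 4 rests on that. It is expected that the step of a number 2 percentage points higher from compound 3 to compound 4 (within the scatter) will be small, of roughly the same size as the measured a number 2 percentage points higher from compound 2 to compound 1 (within the scatter). Compound 4 is therefore estimated at 22%, with a likely range from 8% to 38%.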

Compound 4, a percentage reported as inhibition, at one concentration (the size of the read-out at that concentration, not a potency): 37%
The estimate for compound 4 lay 15 percentage points below the measured number; measured number inside the range.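

Taking away the chloro does not give one fixed step across the two cores in this assay: the same change on two cores in this assay, a number 2 percentage points higher (within the scatter) from compound 2 to compound 1 and a number 17 percentage points higher (beyond the scatter) from compound 3 to compound 4, 15 percentage points apart, beyond the scatter of two such steps

On the core with the nitrile the step is a number 17 percentage points higher from compound 3 to compound 4 (beyond the scatter), so a result from the aldehyde pair would have been a poor guide here, while the swap between the two groups on the core, with no chloro on the attached ring, gives no change at the digits printed from compound 1 to compound 4 (within the scatter). What this does not show is why the two steps differ, since the pairs differ both in the group on the core and in where the chloro sits on the ring, and these compounds cannot separate those two differences.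

The compounds shown leave open how a chloro meta to a large group would read on the core with the aldehyde, which would pull those two differences apart. They also leave open what a carboxylic acid or an amine in place of the nitrile, or a methoxy group in place of the chloro, would give in this assay.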